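The compounds below may be only part of what the source reports. "The series", "measured", "known", "first", "only" and "open" are said of these compounds alone.

Working notes on the series. The shared core runs unchanged through the three measured compounds, which differ only in the aromatic ring on the amide nitrogen. Compound 1 `COc1cc(-c2cc(C(=O)O)c3ccccc3n2)ccc1OCC(=O)Nc1ccccc1` in a physicochemical assay for lipophilicity, using the shake flask method, in phosphate buffer, measured as octanol-water partition, at pH 7.4 (on this read-out higher numbers stand for higher lipophilicity and lower numbers for lower lipophilicity), gives 0.7. Compound 2 `COc1cc(-c2cc(C(=O)O)c3ccccc3n2)ccc1OCC(=O)Nc1ccc(F)cc1` gives 1.1 in this assay, and compound 3 `COc1cc(-c2cc(C(=O)O)c3ccccc3n2)ccc1OCC(=O)Nc1ccc(Cl)cc1` gives 1.5. On these numbers compound 3 stands highest of the three: a number 0.40 log units higher from compound 2 to compound 3 (beyond the scatter), and a number 0.80 log units higher from compound 1 to compound 3 (beyond the scatter). The remaining step, a number 0.40 log units higher from compound 1 to compound 2 (beyond the scatter), completes the picture. Compound 4 `COc1cc(-c2cc(C(=O)O)c3ccccc3n2)ccc1OCC(=O)Nc1ccccc1C(F)(F)F` is not yet measured. The change from compound 3 is 2-(trifluoromethyl)phenyl in place of 4-chlorophenyl on an amide-type nitrogen. Going by the values given here, no measured step covers a trifluoromethyl group, and no measured step changes where a group sits on that ring; the steps that bear on it are a number 0.80 log units higher from compound 1 to compound 3 (beyond the scatter) and a number 0.40 log units higher from compound 2 to compound 3 (beyond the scatter), both modest and upward, and they show only that swapping the substituent on this ring has moved the number by modest amounts within this set. Among the compounds with values here, with no direct precedent, a small upward step or none beyond the scatter is expected in this assay, a number 0.20 log units higher from compound 3 to compound 4 (within the scatter). For compound 4 the estimate in this assay is 1.7, expected to fall between 1.2 and 2.3.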

Compound 4, distribution coefficient: 1.3
The estimate for compound 4 lay 0.40 log units above the measured number; the measured number falls inside the stated range.
By their numbers in this assay, from the lowest: compound 1; then compounds 2, 4 and 3 (each within the scatter of the next, the first and the last beyond it).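

Going by these compounds alone, compound 4 is the first in the set to carry 2-(trifluoromethyl)phenyl on the amide-type nitrogen, and in this assay this gives a number 0.20 log units lower from compound 3 to compound 4 (within the scatter) and a number 0.20 log units higher from compound 2 to compound 4 (within the scatter) so on this read-out the new ring does not separate from 4-chlorophenyl or 4-fluorophenyl. Within the data shown here, there is still a number 0.60 log units higher from compound 1 to compound 4 (beyond the scatter) and so all three substituted compounds now stand beyond the scatter of compound 1, with none of the measured compounds going against this and with the new step as modest as those for fluoro and chloro. No measurement at hand says why the number for this group falls where it does.

Between compound 3 and compound 4 both the substituent and its place on the ring change at once, so the contribution of each cannot be read separately from these compounds. On these data alone, how a nitrile, an amine or a carboxylic acid on this ring would stand against the fluoro, chloro and trifluoromethyl compounds remains open.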